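Compound 2 gets a new amine: what may follow

This account rests on a few compounds, and the source may have more. Where it says the series, first, only, none or still open, it means among the compounds named here.

Measured in an ADME assay on microsomes from intestine (Rattus norvegicus) for metabolic stability, using NADPH, with a stated time of 60 min, in the presence of a further agent that is not named here; a higher number here means that more of the compound is left, a lower number that less of the compound is left:
- Compound 1 `Cc1cncc(-c2cnc3cnn(-c4cccc(N5CCCNCC5)n4)c3c2)n1`: 76%
- Compound 2 `c1cncc(-c2cc3c(-c4cccc(N5CCCNCC5)n4)n[nH]c3cn2)c1`: "unstable" (no number reported)
- Compound 3 `Cc1cncc(-c2cc3c(ccn3-c3cccc(N4CCCNCC4)n3)cn2)n1`: 102%

Compound 2 cannot be placed on the numerical scale. Its entry, "unstable" (no number reported), is a description and not a single number, so it cannot be ranked exactly against the other two compounds. Compound 4 `N[C@H]1CCCN(c2cccc(-c3n[nH]c4cnc(-c5cccnc5)cc34)n2)C1` has not yet been measured. The structural change 3-aminopiperidin-1-yl in place of 1,4-diazepan-1-yl on an aromatic carbon puts 3-aminopiperidin-1-yl in place of 1,4-diazepan-1-yl on an aromatic carbon, and the rest of the structure stays the same.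

Going by the values given here, no measured pair shows this exchange, and compound 2 offers no number to step from. The size of the step in this assay therefore cannot be read from the data. A moderate move towards more compound remaining is expected, but with little confidence, and no change in the outcome would not be surprising. The entry for compound 2, "unstable" (no number reported), holds the expectation down. Compound 1 at 76% and compound 3 at 102% keep it from going very low, although their cores differ from the shared core of compound 2 and compound 4. Compound 4 is estimated at 50%, with an expected range from 15% to 90%.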

Compound 4, percent of the compound remaining: 26%
Compound 4: the middle estimate sits 24 percentage points above what was measured, and the stated range covers the measured number.
By their numbers in this assay, from the lowest: compound 4; then compound 1; then compound 3.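

In this assay, going by these compounds alone, compound 4 gives 26% while compound 2 stands as "unstable" (no number reported) and so no step between compound 2 and compound 4 can be read. Whether 3-aminopiperidin-1-yl in place of 1,4-diazepan-1-yl on the shared core raises or lowers the compound remaining stays open, and nothing shown gives a reason for the result of compound 4.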